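Fluoro for nitro on the benzylidene aryl ring

The source may hold more compounds than are shown below. What is called first, only, known or untested is meant among the compounds shown, and "the series" means these compounds.

Compound 1 `O=C1OC(c2ccc(Cl)cc2)=C/C1=C\c1ccc(Cl)cc1` and compound 2 `O=C1OC(c2ccc(Cl)cc2)=C/C1=C\c1ccc([N+](=O)[O-])cc1` share one core and differ in a single group on the pendant aromatic ring. In a functional assay on the whole organism (strain Wistar) for inhibition, with Rattus norvegicus as the target, with stated times of 30 min and 3 h, at a dose of 20 mg/kg by the oral route (on this read-out higher numbers stand for more inhibition at the one dose given (going by the name of the read-out) and lower numbers for less inhibition), compound 1 gives 69.1%, while compound 2 gives 36%. The step of a number 33.1 percentage points lower from compound 1 to compound 2 (beyond the scatter) is the only measured one, and it leaves compound 2 as the lower of the two numbers. Compound 3 `O=C1OC(c2ccc(Cl)cc2)=C/C1=C\c1ccc(F)cc1` is not yet measured; it differs from compound 2 as follows: fluoro in place of nitro on an aromatic carbon. This change undoes the nitro group and puts a halogen back in the same place, so the measured step from compound 1 to compound 2 bears on it in reverse, and its large size suggests a rise beyond the scatter in this assay. Compound 3 is therefore expected to recover much of what compound 1 showed, with an estimated step of a number 24 percentage points higher from compound 2 to compound 3 (beyond the scatter). The estimate for compound 3 is 60%, within a range of 40% to 78%.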

Compound 3, a percentage reported as inhibition, in the whole organism at one dose (the size of the read-out at that dose, not a potency): 70.4%
Compound 3: the middle estimate sits 10.4 percentage points below what was measured; low and high end bracket the measured number.
By their numbers in this assay, from the lowest: compound 2; then compounds 1 and 3 (each within the scatter of the next).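

Fluoro in place of nitro on an aromatic carbon gives a number 34.4 percentage points higher from compound 2 to compound 3 (beyond the scatter) in this assay, so the low number of compound 2 is not a general feature of the shared core and does not persist once nitro is replaced. Fluoro in place of chloro at the same place gives a number 1.3 percentage points higher from compound 1 to compound 3 (within the scatter), so this assay does not separate the two halogens here, and among the three compounds only the nitro compound stands apart. Nothing given here accounts for the gap between nitro and the two halogens.

The compounds shown leave open whether an amine, a methoxy group or a carboxylic acid at this place would fall with the halogens or with nitro. They also leave open how much the chloro on the other aromatic ring contributes, since all three compounds carry it.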